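Iodo in Place of Amino: an Expected Gain in Inhibition

The source may report more compounds than this note shows. Statements on the series, on what has been measured and on what is new or still open speak of the compounds shown alone.

Compound 1 `CC(=O)OCCOn1cnc2c(Cl)nc(N)nc21` carries an amino group on its core together with a side chain ending in an acetate. In a functional assay (Homo sapiens) for inhibition (a higher number here means a weaker inhibitor, a lower number a stronger inhibitor), compound 1 gives only a limit, > 500000 nM, so its place on the numbers shown is known no more closely than as a limit (the limit of > 500000 nM in this assay, at which 1 of the 2 values shown sits). Compound 2 `CC(=O)OC(C)n1cnc2c(Cl)nc(I)nc21`, which bears an iodo group and a shorter side chain, gives 14500 nM in this assay, a number rather than a limit. Compound 3 `CC(=O)OCCOn1cnc2c(Cl)nc(I)nc21` has not yet been measured. It differs from compound 1 in one place, (iodo in place of amino on an aromatic carbon), that is, iodo in place of amino on an aromatic carbon. Among the compounds with values here, no step between two measured compounds matches this change, so its size must be judged from what compound 2 shows with the same iodo group on the same core. The step is expected to be large and toward stronger inhibition, an at least 16-fold lower number from compound 1 to compound 3 (1.22 log units; beyond the scatter). Compound 3 is therefore estimated at 30000 nM in this assay, with a range from 5000 nM to 200000 nM.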

Compound 3, half-maximal inhibitory concentration: > 500000 nM
Compound 3: only a limit was reported; the forecaster's own chance of this, stated with the estimate: 15%; middle value at least 16-fold (1.22 log units) from the limit.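

Compound 1 and compound 3 both give only a limit in this assay, so no step between them can be read: the limit of > 500000 nM in this assay, at which 2 of the 3 values shown sit.

The compounds shown leave open whether iodo in place of amino on an aromatic carbon changes inhibition at all with this side chain, and by how much.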